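Urea nitrogen substitution in the bicyclic sulfonate thymidine series

This account rests on a few compounds, and the source may have more. Where it says the series, first, only, none or still open, it means among the compounds named here.

Among the compounds with values here, compound 2 `Cc1cn([C@@H]2O[C@H](CO[Si](C)(C)C(C)(C)C)[C@@]3(OS(=O)(=O)C=C3NC(N)=O)[C@H]2O[Si](C)(C)C(C)(C)C)c(=O)n(C)c1=O` provides the only numerical value in an ADME assay on HEL cells (Homo sapiens) for cytotoxicity, with a stated time of 3 days (a lower number here means that less compound is tolerated, a higher number that more compound is tolerated), giving 11000 nM. Compound 1 `Cc1cn([C@@H]2O[C@H](CO[Si](C)(C)C(C)(C)C(C)C)[C@@]3(OS(=O)(=O)C=C3NC(=O)NC(=O)c3ccccc3)[C@H]2O[Si](C)(C)C(C)(C)C(C)C)c(=O)n(C)c1=O` sits at a limit of this assay rather than at a number, > 50000 nM, this being (the limit of > 50000 nM in this assay, at which 1 of the 2 values shown sits). Compound 3 `CCOC(=O)CNC(=O)NC1=CS(=O)(=O)O[C@@]12[C@@H](CO[Si](C)(C)C(C)(C)C)O[C@@H](n1cc(C)c(=O)n(C)c1=O)[C@@H]2O[Si](C)(C)C(C)(C)C` differs from compound 2 by (ethoxycarbonyl)methyl in place of hydrogen on an amide-type nitrogen. Within the data shown here, no measured pair isolates this change, so the step is expected to be modest, a 1.5-fold higher number from compound 2 to compound 3 (0.16 log units; within the scatter), leaning toward more compound being tolerated. Compound 3 is therefore estimated at 16000 nM, with a range from 5000 nM to 50000 nM, and a limit reading is possible.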

Compound 3, half-maximal cytotoxic concentration: 13000 nM
Compound 3: middle estimate off by 1.2-fold (0.09 log units), on the high side; the range from low to high includes it.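

With (ethoxycarbonyl)methyl in place of hydrogen on the amide-type nitrogen, the step in this assay is a 1.2-fold higher number from compound 2 to compound 3 (0.07 log units; within the scatter) and no more. This nitrogen therefore carries an ester-bearing chain without a read-out separable from that of the unsubstituted urea, a single-place comparison that compound 1 and compound 2 could not give. No measurement shown offers a reason for this result.

Open, from the compounds shown here alone, is whether the free carboxylic acid in place of the ethyl ester, a longer chain or an amine on this nitrogen would hold the same level. Going by these compounds, whether any substituent here moves the read-out beyond the scatter also remains open.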